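Benzyl variation on the triazole ether of the series

The compounds below may be only part of what the source reports. "The series", "measured", "known", "first", "only" and "open" are said of these compounds alone.

Among the compounds with values here, compound 2 `COc1ccc([C@@H]2CC(=O)c3c(O)cc(OCc4cn(Cc5ccc(C)cc5)nn4)cc3O2)cc1O` gives 16800 nM in a functional assay on RAW264.7 cells (Mus musculus) for inhibition, read by Griess assay, with stated times of 2 h and 24 h (on this read-out lower numbers stand for stronger inhibition and higher numbers for weaker inhibition), the lowest of the two numbers so far, though within the scatter of compound 1 `COc1ccc([C@@H]2CC(=O)c3c(O)cc(OCc4cn(Cc5cccc(C#N)c5)nn4)cc3O2)cc1O`, which gives 18000 nM. Within the data shown here, the one measured step at this position, a 1.1-fold lower number from compound 1 to compound 2 (0.03 log units; within the scatter), stayed within the scatter. Compound 3 `COc1ccc([C@@H]2CC(=O)c3c(O)cc(OCc4cn(Cc5cccc(C(F)(F)F)c5)nn4)cc3O2)cc1O` carries 3-(trifluoromethyl)phenyl in place of 4-methylphenyl on a saturated chain carbon bound to an aromatic nitrogen, that is, 3-(trifluoromethyl)benzyl for 4-methylbenzyl. Among the measured compounds shown here, since the only comparable step did not move the number, no step beyond the scatter is expected in this assay in either direction. Compound 3 is therefore estimated at 17000 nM, between 8000 nM and 36000 nM. For compound 3 this means an expected step of a 1.0-fold higher number from compound 2 to compound 3 (0.01 log units; within the scatter).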

Compound 3, half-maximal inhibitory concentration: 19900 nM
Estimate against measurement, compound 3: 1.2-fold (0.07 log units) below, and the stated range covers the measured number.
By their numbers in this assay, from the lowest: compounds 2, 1 and 3 (each within the scatter of the next).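

In this assay, 3-(trifluoromethyl)benzyl for 4-methylbenzyl gives a 1.2-fold higher number from compound 2 to compound 3 (0.07 log units; within the scatter), and trifluoromethyl in place of cyano on an aromatic carbon gives a 1.1-fold higher number from compound 1 to compound 3 (0.04 log units; within the scatter). All three substituted benzyl compounds thus lie within the scatter of one another, so this third group adds no separation at this position. No accompanying data bear on this lack of separation.

On these data alone, it remains open whether an amine, a carboxylic acid or a longer chain in place of the substituted phenyl, on the saturated chain carbon bound to an aromatic nitrogen, would move the number beyond the scatter.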